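Swapping the aryl amide for a sulfone-bearing ring

A few compounds are considered here, and "the series" means these few. Any claim that something is new, unique, unknown or untested is made for them only; others in the source may bear on it.

Measured compounds:
- compound 1 `CC(C)CN1CCCC[C@H]1C(=O)Nc1cc(C(C)(C)C)on1`: 32 ug/mL
- compound 2 `CC(C)(C)c1cc(NC(=O)[C@@H]2CCCCN2C2CCOCC2)no1`: 74 ug/mL
- compound 3 `CC(C)(C)c1cc(NC(=O)[C@@H]2CCCCN2C(=O)c2ccc(Cl)cc2)no1`: < 0.1 ug/mL

In a physicochemical assay for solubility, read by HPLC, at pH 6.8 (on this read-out lower numbers stand for lower solubility and higher numbers for higher solubility), compound 3 gives only a limit, < 0.1 ug/mL, not a number; it sits at the limit of < 0.1 ug/mL in this assay, at which 1 of the 3 values shown sits. Compound 4 `CC(C)(C)c1cc(NC(=O)[C@@H]2CCCCN2C(=O)C2CCS(=O)(=O)CC2)no1` keeps the whole of compound 3 except one group: 1,1-dioxothian-4-yl in place of 4-chlorophenyl on a carbonyl carbon. For the measured compounds named here, no measured pair changes the group on this carbonyl carbon, so the step has no direct precedent. The measured steps that touch this part of the molecule are an at least 320-fold lower number from compound 1 to compound 3 (2.50 log units; beyond the scatter) and an at least 740-fold lower number from compound 2 to compound 3 (2.86 log units; beyond the scatter), both large drops when the (4-chlorophenyl)carbonyl group entered on the ring nitrogen. Compound 4 keeps that carbonyl and changes only the ring attached to it, so the expectation rests on the size of the gap below compounds 1 and 2 rather than on a matching example. For compound 4 a rise from the limit is expected, an at least 50-fold higher number from compound 3 to compound 4 (1.69 log units; beyond the scatter), though likely not back to the level of compound 1. The estimate for compound 4 in this assay is 5 ug/mL, within a range of 0.5 ug/mL to 40 ug/mL.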

Compound 4, solubility: 67 ug/mL
Beside the measured number, compound 4's estimate is 13-fold (1.13 log units) below it; measured number outside the range, above it.
By their numbers in this assay, from the lowest: compound 1; then compounds 4 and 2 (each within the scatter of the next). At a limit, below all of these: compound 3.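

In this assay, changing only the ring on this carbonyl carbon gives an at least 670-fold higher number from compound 3 to compound 4 (2.82 log units; beyond the scatter). The earlier compounds shown here showed only a drop when the whole (4-chlorophenyl)carbonyl group replaced isobutyl or oxan-4-yl on the ring nitrogen; with the carbonyl kept and 1,1-dioxothian-4-yl in place of 4-chlorophenyl, compound 4 at 67 ug/mL sits within the scatter of compound 2 at 74 ug/mL, so a carbonyl in this place does not by itself hold the number down. The true size of the step stays unknown, as compound 3 gives a limit, not a number: the limit of < 0.1 ug/mL in this assay, at which 1 of the 4 values shown sits.

The compounds shown do not tell whether the two ring oxygens and sulfur matter, or simply the loss of the chlorine or the aromatic ring. A plain phenyl or a cyclohexyl on the same carbonyl carbon would separate these.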